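The source may hold more compounds than are shown below. What is called first, only, known or untested is meant among the compounds shown, and "the series" means these compounds.

In a functional assay on the whole organism (stomach) for inhibition, with Canis familiaris (Canis lupus familiaris) as the target, at a dose of 5 mg/kg by the intravenous route (on this read-out lower numbers stand for a weaker effect and higher numbers for a stronger effect at the one dose given), compound 1 `Cc1cn2cccc(OCc3ccccc3)c2n1` gives 70%, while compound 2 `Cc1nc2c(OCc3ccccc3)cccn2c1C#N` gives 4%, the lowest of the two numbers shown; the step of a number 66 percentage points lower from compound 1 to compound 2 (beyond the scatter) is large. Compound 3 `COCc1c(C)nc2c(OCc3ccccc3)cccn12` differs from compound 2 by methoxymethyl in place of cyano on an aromatic carbon. Within the data shown here, the only measured step bears on this change, since it introduced the cyano that now leaves, although what enters is methoxymethyl rather than hydrogen. A rise beyond the scatter is therefore expected, and a number 36 percentage points higher from compound 2 to compound 3 (beyond the scatter) is the estimated size of that step. Compound 3 is expected to give 40%, within 10% to 75%.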

Compound 3, a percentage reported as inhibition, in the whole organism at one dose (the size of the read-out at that dose, not a potency): 29%
Compound 3: middle estimate off by 11 percentage points, on the high side; measured number inside the range.
By their numbers in this assay, from the lowest: compound 2; then compound 3; then compound 1.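

In this assay, methoxymethyl in place of cyano gives a number 25 percentage points higher from compound 2 to compound 3 (beyond the scatter) and so recovers only part of the effect, while methoxymethyl in place of hydrogen gives a number 41 percentage points lower from compound 1 to compound 3 (beyond the scatter) at this same position. The loss at this aromatic carbon is therefore not confined to cyano, although the two groups do not give the same outcome. Nothing available here explains the difference between these groups. The compounds shown leave open whether a small group such as fluorine or methyl would stay closer to compound 1. They also leave open how an amine or a hydroxymethyl would behave at this position.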